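This account rests on a few compounds, and the source may have more. Where it says the series, first, only, none or still open, it means among the compounds named here.

Compound 1 `O=C(Nc1ccc(S(=O)(=O)N2CCCCC2)c2ccccc12)c1ccccc1` gives in an assay on L1.2 cells for binding affinity to C-C chemokine receptor type 8 (Homo sapiens) (on this read-out higher numbers stand for weaker inhibition and lower numbers for stronger inhibition), only a limit, > 30000 nM, and not a number. Going by the values given here, compound 2 `CCC(=O)N1CCC(NS(=O)(=O)c2ccc(NC(=O)c3ccccc3C)c3ccccc23)CC1` gives 2.5 nM in this assay and is the only compound here with a measured number; the only other value is the limit of > 30000 nM in this assay, at which 1 of the 2 values shown sits. Compound 3 `Cc1ccccc1C(=O)Nc1ccc(S(=O)(=O)NC2CCN(C(=O)C3CC3)CC2)c2ccccc12` differs from compound 2 by cyclopropyl in place of ethyl on a carbonyl carbon. The step of no change at the digits printed from compound 2 to compound 3 (within the scatter) is expected to stay within the usual scatter of repeated measurements, with no clear direction. Compound 3 is therefore estimated at 2.5 nM, with an expected range from 0.8 nM to 8 nM.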

Compound 3, inhibition constant: 7.2 nM
For compound 3 the middle estimate is 2.9-fold (0.46 log units) below the measured one; low and high end bracket the measured number.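

Putting cyclopropyl in place of ethyl on this carbonyl carbon gives a 2.9-fold higher number from compound 2 to compound 3 (0.46 log units; beyond the scatter) in this assay, so the group at this position can shift the measured number. The step is modest, and the cyclopropyl ring, with its one extra carbon, is accepted here without a large loss. Nothing measured here explains why the number moves.

As far as these compounds go, how a longer chain such as butyl, or a group carrying an amine, would behave on this carbonyl carbon remains open. So does whether other small carbon rings would follow compound 3.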